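The source may report more compounds than this note shows. Statements on the series, on what has been measured and on what is new or still open speak of the compounds shown alone.

Within the data shown here, compound 1, with the structure `CSc1ccc(N(C)c2nc(C)nc3ccccc23)cc1`, is one of three compounds measured in a functional assay on MDA-MB-435 cells (Homo sapiens) for antiproliferative activity, read by sulforhodamine B assay (a lower number here means a stronger inhibitor, a higher number a weaker inhibitor), where compound 1 gives 1.2 nM. Compound 3, with the structure `CSc1ccc(N(C)c2nc(Cl)nc3ccccc23)cc1`, carries a single change relative to compound 1, namely (chloro in place of methyl on an aromatic carbon). In this assay compound 3 gives 2.7 nM, so the step is a 2.3-fold higher number from compound 1 to compound 3 (0.35 log units; beyond the scatter).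

Compound 2, with the structure `COc1cccc2cc(N(C)c3nc(C)nc4ccccc34)ccc12`, is built on a different core; the difference between the two cores is not broken down here. In this assay compound 2 gives 2 nM, a value that lies close to those of compound 1 and compound 3.

Compound 4, with the structure `COc1cccc2cc(N(C)c3nc(Cl)nc4ccccc34)ccc12`, has not yet been measured. Relative to compound 2 it carries chloro in place of methyl on an aromatic carbon, the same change that turns compound 1 into compound 3. Because the earlier step of a 2.3-fold higher number from compound 1 to compound 3 (0.35 log units; beyond the scatter) was modest, the step from compound 2 to compound 4 is expected to be similar, about a 2.3-fold higher number from compound 2 to compound 4 (0.35 log units; beyond the scatter) in this assay. For compound 4 the value in this assay is therefore estimated at 4.5 nM, likely between 2.5 nM and 9 nM.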

Compound 4, half-maximal inhibitory concentration: 1.4 nM
Compound 4: the middle estimate sits 3.2-fold (0.51 log units) above what was measured; the whole stated range lies above it.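

On the core of compound 2, placing chloro where methyl stood gives a 1.4-fold lower number from compound 2 to compound 4 (0.15 log units; within the scatter) in this assay, so on this core the change produces no difference that can be told from the scatter. Set beside the earlier step, the same change does not carry over unchanged from one core to the other: the same change on two cores in this assay, a 2.3-fold higher number (0.35 log units; beyond the scatter) from compound 1 to compound 3 and a 1.4-fold lower number (0.15 log units; within the scatter) from compound 2 to compound 4, 3.2-fold (0.51 log units) apart, beyond the scatter of two such steps. Among these compounds, this shows that a step read on one core cannot simply be added to a compound on the other core, but with only two pairs it does not show what in the cores causes the gap, nor which of the two steps would be the more usual on a further core.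

As far as these compounds go, it remains open how an amine, a longer chain such as ethyl, or a carboxylic acid would read at this aromatic carbon between two ring nitrogen atoms, since only methyl and chloro appear there. From the compounds shown here alone, it also remains open whether chloro in place of methyl would follow either step on a third core.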